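The source may report more compounds than this note shows. Statements on the series, on what has been measured and on what is new or still open speak of the compounds shown alone.

Compound 1 `COC(=O)c1sc2cc(C#Cc3ccc(OC)cc3)cnc2c1N` is one of the measured set. In a functional assay on A375-C5 cells (Homo sapiens) for inhibition, read by sulforhodamine B assay, with a stated time of 48 h (on this read-out lower numbers stand for stronger inhibition of growth and higher numbers for weaker inhibition of growth), compound 1 gives > 37500 nM, which is a limit of the assay. Compound 2 `COC(=O)c1sc2cc(C#Cc3ccccc3F)cnc2c1N` belongs to the same set. In this assay compound 2 gives > 150000 nM, again a limit. Compound 3 `COC(=O)c1sc2cc(C#Cc3ccccc3OC)cnc2c1N` completes it. In this assay compound 3 gives > 47300 nM, also a limit.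

Compound 3 therefore stands at a limit, and the two other values are limits too the limit of > 150000 nM in this assay, at which 1 of the 3 values shown sits, the limit of > 37500 nM in this assay, at which 1 of the 3 values shown sits (the limit of > 47300 nM in this assay, at which 1 of the 3 values shown sits). The steps between them, a step that the two limits leave unreadable from compound 1 to compound 2, a step that the two limits leave unreadable from compound 1 to compound 3 and a step that the two limits leave unreadable from compound 2 to compound 3, cannot be read.

Compound 4 `COC(=O)c1sc2cc(C#Cc3cccnc3)cnc2c1N` differs from compound 3 in one place: pyridin-3-yl in place of 2-methoxyphenyl on a triple-bonded carbon. For the measured compounds named here, no measured step bears on a pyridin-3-yl group, and none of the three measured steps gives a readable size, so nothing supports a change beyond the scatter in this assay. Compound 4 is expected to give 100000 nM, with a range from 30000 nM to 300000 nM, most likely reported only as a limit. The expected step is a step that the limit leaves unreadable from compound 3 to compound 4, none beyond the scatter.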

Compound 4, concentration for 50% growth inhibition: > 150000 nM
Compound 4 was reported as a limit; the forecaster's own chance of this, stated with the estimate: 85%; middle value at least 1.5-fold (0.17 log units) away from the limit.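

In this assay compound 4 gives > 150000 nM, which is a limit. For the compounds shown here, compounds 1, 2 and 3 also stand at limits, so no step from any of them to compound 4 can be read. The compounds shown leave open whether these groups on the triple-bonded carbon differ at all in growth inhibition.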